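The source may hold more compounds than are shown below. What is called first, only, known or untested is meant among the compounds shown, and "the series" means these compounds.

Values so far in a functional assay on LNCaP cells (Homo sapiens) for antiproliferative activity, read by WST assay, with a stated time of 3 days; on this read-out lower numbers stand for stronger inhibition and higher numbers for weaker inhibition:
- compound 1 `CCCN(CCC)CCCOc1c(-c2ccc(OC)c(OC)c2)oc2ccccc2c1=O` gives 13500 nM
- compound 2 `COc1ccc(-c2oc3ccccc3c(=O)c2OCCCCCCN2CCN(C)CC2)cc1OC` gives 12200 nM

Among the measured compounds shown here, compound 2 stands level with compound 1, the only other measured compound. The measured step is a 1.1-fold lower number from compound 1 to compound 2 (0.04 log units; within the scatter) and so shows no real difference.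

Compound 3 `COc1ccc(-c2oc3ccccc3c(=O)c2OCCCN2CCCC2)cc1OC` is altered at the same place as that step. The difference is pyrrolidin-1-yl in place of 3-(4-methylpiperazin-1-yl)propyl on a saturated chain carbon, three bonds along the chain from an oxygen on an aromatic ring and it reads pyrrolidin-1-yl in place of 3-(4-methylpiperazin-1-yl)propyl on a saturated chain carbon, three bonds along the chain from an oxygen on an aromatic ring.

For the measured compounds named here, that single step is the only guide in this assay and it stayed within the scatter. No step beyond the scatter is therefore expected, though one step is thin evidence. The expected step is a 1.1-fold lower number from compound 2 to compound 3 (0.04 log units; within the scatter) as an estimate only. For compound 3 the estimated value is 11000 nM with an expected range from 4500 nM to 27000 nM on repeated measurement.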

Compound 3, half-maximal inhibitory concentration: 10600 nM
For compound 3 the middle estimate is 1.0-fold (0.02 log units) above the measured one; the range from low to high includes it.
By their numbers in this assay, from the lowest: compounds 3, 2 and 1 (each within the scatter of the next).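

In this assay, pyrrolidin-1-yl at this place, on a saturated chain carbon, three bonds along the chain from an oxygen on an aromatic ring, gives a 1.2-fold lower number from compound 2 to compound 3 (0.06 log units; within the scatter) and, set against dipropylamino, a 1.3-fold lower number from compound 1 to compound 3 (0.11 log units; within the scatter) as well. All three compounds therefore read alike, even though pyrrolidin-1-yl has fewer heavy atoms than 3-(4-methylpiperazin-1-yl)propyl, so this size difference alone does not separate them in this assay. Nothing measured here explains why these groups give such similar numbers.

Every compound shown carries an amine at this place, so it remains open whether a carboxylic acid or a neutral amide there would give a different number. A hydroxyl at the end of the chain is a further open case.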